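Swapping a methyl for a carbamoyl on the thiazole core

The source may hold more compounds than are shown below. What is called first, only, known or untested is meant among the compounds shown, and "the series" means these compounds.

Compound 1 `Cc1cccc(Nc2nc(-c3ccncc3)c(C)s2)c1` gives 10000 nM in a functional assay on RCC4 cells (Homo sapiens) for inhibition, read by XTT assay, with a stated time of 4 days; on this read-out lower numbers stand for stronger inhibition and higher numbers for weaker inhibition; this is the only number shown for it, with one more entry that gives no single value. Compound 2 `Cc1cccc(Nc2nc(-c3ccnc(-c4cnn(Cc5ccccc5)c4)c3)cs2)c1` gives 2200 nM; 2240 nM (2 entries) in this assay. Compound 3 `Cc1cccc(Nc2nc(-c3ccncc3)c(C(N)=O)s2)c1` differs from compound 1 by carbamoyl in place of methyl on an aromatic carbon. Among the compounds with values here, with no measured step of this kind available, the expected change a 1.4-fold lower number from compound 1 to compound 3 (0.15 log units; within the scatter) is small, and no direction beyond the scatter is expected. Compound 3 is therefore expected at about 7000 nM, with a range from 1500 nM to 20000 nM.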

Compound 3, half-maximal inhibitory concentration: 19500 nM
Estimate against measurement, compound 3: 2.8-fold (0.44 log units) below; low and high end bracket the measured number.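

Carbamoyl in place of methyl on the aromatic carbon next to the ring sulfur gives a 2.0-fold higher number from compound 1 to compound 3 (0.29 log units; within the scatter) in this assay. So swapping methyl for this larger group, which adds a hydrogen-bond donor and acceptor, produces no change that can be told apart from the usual scatter. Repeat readings can still agree closely: the several entries of compound 2 in this assay, 2200 nM; 2240 nM (2 entries)

From the compounds shown here alone, whether an amine, a carboxylic acid or a longer chain on this carbon would move the number beyond the scatter stays open. So does whether carbamoyl would behave the same way on the core of compound 2.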